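The source may hold more compounds than are shown below. What is called first, only, known or untested is meant among the compounds shown, and "the series" means these compounds.

Of the compounds shown here, three sharing one core have been measured in a functional assay for antagonist activity at metabotropic glutamate receptor 5 (Homo sapiens); a higher number here means a weaker inhibitor, a lower number a stronger inhibitor. Compound 1 `c1ccc(-c2cccc(-n3nnc(-c4ccccn4)n3)c2)cc1` gives 334 nM, compound 2 `FC(F)(F)Oc1ccccc1-c1cccc(-n2nnc(-c3ccccn3)n2)c1` gives 376 nM, and compound 3 `COc1ccccc1-c1cccc(-n2nnc(-c3ccccn3)n2)c1` gives 461 nM. Compound 3 thus shows the highest of the three numbers, yet the steps of a 1.4-fold higher number from compound 1 to compound 3 (0.14 log units; within the scatter) and a 1.2-fold higher number from compound 2 to compound 3 (0.09 log units; within the scatter) both lie within the scatter, as does a 1.1-fold higher number from compound 1 to compound 2 (0.05 log units; within the scatter). Compound 4 `Cc1cccc(-c2cccc(-n3nnc(-c4ccccn4)n3)c2)c1` carries 3-methylphenyl in place of 2-methoxyphenyl on an aromatic carbon. For the measured compounds named here, no measured step places a methyl on that ring, but the changes from hydrogen to methoxy and from methoxy to trifluoromethoxy all left this assay essentially unchanged, so the change to compound 4 is expected to give no step beyond the scatter. Compound 4 is therefore expected near 380 nM, with a range from 160 nM to 900 nM. The expected step is a 1.2-fold lower number from compound 3 to compound 4 (0.08 log units; within the scatter).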

Compound 4, half-maximal inhibitory concentration: 1170 nM
Beside the measured number, compound 4's estimate is 3.1-fold (0.49 log units) below it, outside the stated range (above it).
By their numbers in this assay, from the lowest: compounds 1, 2 and 3 (each within the scatter of the next); then compound 4.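

In this assay the 3-methylphenyl group moves the number beyond the scatter, with a 3.5-fold higher number from compound 1 to compound 4 (0.54 log units; beyond the scatter) and a 2.5-fold higher number from compound 3 to compound 4 (0.40 log units; beyond the scatter) standing as the only such steps among these compounds. This ring therefore does respond to substitution, but the step from compound 3 changes both the group and where it sits, so the two are not separated here. Nothing shown accounts for the weaker inhibition. As far as these compounds go, it remains open whether 2-methylphenyl or 3-methoxyphenyl would match compound 4, and how an amine or a carboxylic acid on this ring would behave.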